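From tert-butyl to difluoromethoxy: notes on compound 4

The source may report more compounds than this note shows. Statements on the series, on what has been measured and on what is new or still open speak of the compounds shown alone.

Measured in a functional assay on M21 cells (Homo sapiens) for antiproliferative activity, read by sulforhodamine B assay, with a stated time of 48 h; on this read-out higher numbers stand for weaker inhibition and lower numbers for stronger inhibition:
- compound 1 `O=C1NCCN1c1ccc(S(=O)(=O)Nc2ccc(C3CCCCC3)cc2)cc1`: > 1000 nM (a limit)
- compound 2 `O=C1NCCN1c1ccc(S(=O)(=O)Nc2ccccc2)cc1`: 200 nM
- compound 3 `CC(C)(C)c1ccc(NS(=O)(=O)c2ccc(N3CCNC3=O)cc2)cc1`: > 1000 nM (a limit)

Compound 3 stands at > 1000 nM, which is a limit and not a number. The change under review gives compound 4 `O=C1NCCN1c1ccc(S(=O)(=O)Nc2ccc(OC(F)F)cc2)cc1`, with difluoromethoxy in place of tert-butyl on an aromatic carbon. Two measured steps change the group at this place and bear on it. These are an at least 5.0-fold higher number from compound 2 to compound 3 (0.69 log units; beyond the scatter) and an at least 5.0-fold lower number from compound 1 to compound 2 (0.69 log units; beyond the scatter). The third, a step that the two limits leave unreadable from compound 1 to compound 3, adds nothing. Going by the values given here, no measured compound carries difluoromethoxy, so the expectation is loose. Compound 2, with hydrogen at this place, gives 200 nM, and a group at this place is expected to keep compound 4 from going much lower than that. A modest move to a lower number is expected in this assay, though another limit reading remains possible. The expected step is an at least 1.6-fold lower number from compound 3 to compound 4 (0.22 log units; that floor lies within the scatter). For compound 4 the estimate is 600 nM, with an expected range from 200 nM to 1800 nM.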

Compound 4, half-maximal inhibitory concentration: 410 nM
For compound 4 the middle estimate is 1.5-fold (0.17 log units) above the measured one, and the stated range covers the measured number.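

In this assay compound 4 is the only compound shown with a group at this place that reads as a number and not as a limit. Difluoromethoxy gives an at least 2.4-fold lower number from compound 3 to compound 4 (0.38 log units; beyond the scatter) and an at least 2.4-fold lower number from compound 1 to compound 4 (0.38 log units; beyond the scatter), so a group at this place does not by itself push the reading to the limit, even though tert-butyl and difluoromethoxy have the same heavy-atom count. Against hydrogen the group still costs potency, and this cost now has a readable size: a 2.1-fold higher number from compound 2 to compound 4 (0.31 log units; beyond the scatter).

Going by these compounds, the step between compound 1 and compound 3 cannot be read, and the true distance of either compound from compound 4 stays unknown: the limit of > 1000 nM in this assay, at which 2 of the 4 values shown sit. On these data alone, whether methoxy or an amine at this place would match difluoromethoxy, or come closer to hydrogen, remains open.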